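The source may report more compounds than this note shows. Statements on the series, on what has been measured and on what is new or still open speak of the compounds shown alone.

So far three related compounds have numbers in a functional assay on MDA-MB-231 cells (Homo sapiens) for antiproliferative activity, read by sulforhodamine B assay, with a stated time of 72 h (on this read-out lower numbers stand for stronger inhibition and higher numbers for weaker inhibition), for comparison. Compound 1 (`CC(C)C[C@H](NC(=O)CSc1cc(NS(=O)(=O)c2ccccc2)c2ccccc2c1O)B(O)O`) gives 10600 nM and compound 2 (`CC(C)C[C@H](NC(=O)CSc1cc(NS(=O)(=O)c2cccs2)c2ccccc2c1O)B(O)O`) gives 6520 nM in this test. Compound 3 (`Cc1ccc(S(=O)(=O)Nc2cc(SCCC(=O)N[C@@H](CC(C)C)B(O)O)c(O)c3ccccc23)cc1`) gives 6150 nM in the same test, which lies within the usual scatter of both other compounds, so the three cannot be ranked.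

Compound 4 (`CC(=O)Nc1ccc(S(=O)(=O)Nc2cc(SCCC(=O)N[C@@H](CC(C)C)B(O)O)c(O)c3ccccc23)cc1`) differs from compound 3 in one place. On an aromatic carbon of a six-membered aromatic ring of carbon only, para to a large group, acetamido stands in place of methyl (acetamido in place of methyl on an aromatic carbon), which turns 4-methylphenyl into 4-acetamidophenyl.

For the measured compounds named here, no measured pair shows this exact swap. Going by the values given here, the only measured step on the group at the sulfonyl sulfur is a 1.6-fold lower number from compound 1 to compound 2 (0.21 log units; within the scatter) for thiophen-2-yl in place of phenyl, which lies within the scatter, and from it no step beyond the scatter is expected in this assay in either direction. This is a thin guide, as that step exchanges a whole ring and not a single group on it. The estimated step is a 1.1-fold higher number from compound 3 to compound 4 (0.02 log units; within the scatter) and it would be too small to read as a real change. For compound 4 the estimated value is 6500 nM (expected range 2800 nM to 15000 nM).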

Compound 4, half-maximal inhibitory concentration: 2120 nM
Compound 4: middle estimate off by 3.1-fold (0.49 log units), on the high side; the whole stated range lies above it.
By their numbers in this assay, from the lowest: compound 4; then compounds 3, 2 and 1 (each within the scatter of the next).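

Acetamido in place of methyl gives a 2.9-fold lower number from compound 3 to compound 4 (0.46 log units; beyond the scatter) in this assay, the first step in this series to lie beyond the scatter. It shows that changing only the group on this aromatic carbon, para to a large group, can shift the number, whereas the earlier exchange of the whole ring on the sulfonyl sulfur stayed within the scatter. The change adds heavy atoms, a hydrogen-bond donor and a hydrogen-bond acceptor all at once, and nothing measured here says which of these matters or why the number falls.

A free amine, a carboxylic acid or a longer acyl chain such as propionamido at the same place would help show whether the whole acetamido group is needed or only part of it. Going by these compounds, it also remains open whether acetamido would give a similar step on the core of compound 1, whose chain on the sulfur differs from that of compound 3.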